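The source may report more compounds than this note shows. Statements on the series, on what has been measured and on what is new or still open speak of the compounds shown alone.

Series notes, measured in an ADME assay on microsomes from liver (Homo sapiens) for metabolic stability, using NADPH, with a stated time of 10 min; on this read-out higher numbers stand for a more stable compound and lower numbers for a less stable compound:

- compound 1 `NCCCCN(C[C@@H]1Cc2cccnc2CN1)[C@H]1CCCc2cccnc21`: 92%
- compound 2 `NCCCCN(C[C@@H]1Cc2nccnc2CN1)[C@H]1CCCc2cccnc21`: 87%
- compound 3 `CN(C[C@H]1Cc2ncccc2CN1)[C@H]1CCCc2cccnc21`: 95%

Compound 3 at 95% lies within the usual scatter of both compound 1 and compound 2, so the three measured compounds cannot be separated on this read-out.

The next compound is compound 4 `CCN(CC)CCCCN(C[C@H]1Cc2ncccc2CN1)[C@H]1CCCc2cccnc21`. Against compound 3 it differs by 3-(diethylamino)propyl in place of hydrogen on a saturated chain carbon bound to an amine nitrogen, with 3-(diethylamino)propyl in place of hydrogen on a saturated chain carbon bound to an amine nitrogen.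

Within the data shown here, no measured pair isolates a change of this kind, so the series gives no direct guide to its size. The direction rests on a simple point: with compound 3 at 95%, the scale leaves little room upward. The measured values also sit close together, and compound 2 at 87% is the only further reference, so the size of any fall remains poorly defined and the range is kept wide.

In this assay a fall beyond the scatter is expected, estimated as a number 20 percentage points lower from compound 3 to compound 4 (beyond the scatter). For compound 4 the estimated value is 75%, with an expected range of 50% to 95%.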

Compound 4, percent of the compound remaining: 80%
Beside the measured number, compound 4's estimate is 5 percentage points below it; measured number inside the range.
By their numbers in this assay, from the lowest: compounds 4, 2, 1 and 3 (each within the scatter of the next, the first and the last beyond it).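

In this assay, among these compounds, the change of 3-(diethylamino)propyl in place of hydrogen on a saturated chain carbon bound to an amine nitrogen gives a number 15 percentage points lower from compound 3 to compound 4 (beyond the scatter) as the first step between compounds that differ in one place. This shows that the read-out does respond at this position, which the earlier values could not show, yet the step stays modest: with 8 heavy atoms added, compound 4 at 80% still keeps most of the compound in the assay. No supporting data bear on why the value falls at this position, so the step stands as an observation only.

A single step leaves the contribution of the chain length and that of the diethylamino end unseparated, and it says nothing on whether the same change would give a step of similar size on the cores of compound 1 and compound 2. Also open, on these data alone, is how this position would respond to a longer chain, or to a chain ending in a morpholine or a carboxylic acid instead of the diethylamino group.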